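Cyclopropyloxy in place of isopropoxy on the aryl ether

The source may report more compounds than this note shows. Statements on the series, on what has been measured and on what is new or still open speak of the compounds shown alone.

Compound 1 `CC(Oc1ccccc1Br)C1=NCCN1`: 10 nM
Compound 2 `CC(C)Oc1ccccc1OC(C)C1=NCCN1`: 100 nM

Among the compounds with values here, in a functional assay on CHO cells for agonist activity at Alpha-2C adrenergic receptor (Homo sapiens) (a higher number here means that more compound is needed for the effect, a lower number that less compound is needed), compound 2 gives the highest of the two numbers measured; its nearest neighbour is compound 1, and the only measured step, a 10-fold higher number from compound 1 to compound 2 (1.00 log units; beyond the scatter), separates them. Compound 3 `CC(Oc1ccccc1OC1CC1)C1=NCCN1` has not yet been measured. It differs from compound 2 in one place: cyclopropyl in place of isopropyl on an oxygen on an aromatic ring. Within the data shown here, no measured step bears directly on this exchange; the single known step concerns bromo against isopropoxy on the aromatic carbon, not one alkyl against another on the ether oxygen. The change is therefore judged without precedent among these compounds, and a step no larger than the scatter, or a modest one in either direction, is expected. Compound 3 is estimated at 70 nM in this assay, within 20 nM to 250 nM, which corresponds to an expected step of a 1.4-fold lower number from compound 2 to compound 3 (0.15 log units; within the scatter).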

Compound 3, half-maximal effective concentration: 47.9 nM
For compound 3 the middle estimate is 1.5-fold (0.16 log units) above the measured one, and the stated range covers the measured number.
By their numbers in this assay, from the lowest: compound 1; then compound 3; then compound 2.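

In this assay, the group on the ether oxygen matters even when its size in heavy atoms stays the same: cyclopropyl in place of isopropyl gives a 2.1-fold lower number from compound 2 to compound 3 (0.32 log units; beyond the scatter), a modest change but one printed as beyond the scatter. Replacing bromo with cyclopropyloxy still gives a 4.8-fold higher number from compound 1 to compound 3 (0.68 log units; beyond the scatter), so the cyclopropyl ether recovers only part of the gap, and compound 1 keeps the lowest number of the three. No evidence is available to explain either step.

The compounds shown leave open whether a different group on the oxygen, such as methyl, ethyl or cyclobutyl, would bring the number closer to that of compound 1. They also do not show how an amine or a nitrile would compare with bromo on the same aromatic carbon.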